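The compounds below may be only part of what the source reports. "The series", "measured", "known", "first", "only" and "open" are said of these compounds alone.

Compound 1, `CNS(=O)(=O)c1cc(C(=O)O)ccc1NCCCCCCCC(F)(F)F`, is the starting point. In an ADME assay on a cell-free system (plasma, Mus musculus) for metabolic stability, tested at 5 uM (a higher number here means that the compound lasts longer, a lower number that the compound disappears faster), compound 1 gives > 2 h, which is a limit of the assay rather than a number. Two measured relatives alter only the group on the sulfonyl sulfur. Compound 2, `O=C(O)c1ccc(NCCCCCCCC(F)(F)F)c(S(=O)(=O)N2CCCC2)c1`, carries pyrrolidin-1-yl in place of methylamino on a sulfonyl sulfur; in this assay compound 2 gives > 2 h, again a limit of the assay. Compound 3, `O=C(O)c1ccc(NCCCCCCCC(F)(F)F)c(S(=O)(=O)N2CCOCC2)c1`, carries morpholin-4-yl in place of methylamino on a sulfonyl sulfur; in this assay compound 3 gives > 2 h, also a limit. Because all three sit at the limit of > 2 h in this assay, at which 3 of the 3 values shown sit, the steps a step that the two limits leave unreadable from compound 1 to compound 2, a step that the two limits leave unreadable from compound 1 to compound 3 and a step that the two limits leave unreadable from compound 2 to compound 3 cannot be sized. The unmeasured compound 4, `O=C(O)c1ccc(NCCCCCCCC(F)(F)F)c(S(=O)(=O)NC2CCCCC2)c1`, differs from compound 1 by cyclohexyl in place of methyl on a sulfonamide nitrogen. Within the data shown here, the measured steps all concern the group on the sulfonyl sulfur, whereas compound 4 changes the sulfonamide nitrogen, so none bears directly on it, and none can be read in any case; they show only that three relatives of compound 1 all lasted past the limit. No change beyond the scatter is therefore expected, and the step that the limit leaves unreadable from compound 1 to compound 4 is an estimate of little movement. Compound 4 is expected to give 3 h, within 1.5 h to 8 h.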

Compound 4, half-life: > 2 h
Compound 4: only a limit was reported; the forecaster's own chance of this, stated with the estimate: 75%; the middle value is on the limit's open side.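

In this assay compound 4 gives > 2 h, which is a limit of the assay and not a number. The steps to compound 4 from compound 1, compound 2 and compound 3 cannot be read, because all four compounds sit at the same limit: the limit of > 2 h in this assay, at which 4 of the 4 values shown sit. As far as these compounds go, how long each of the four actually lasts, and whether they differ at all, stays open.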